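A few compounds are considered here, and "the series" means these few. Any claim that something is new, unique, unknown or untested is made for them only; others in the source may bear on it.

Compound 1, `Cc1cc(O)c(C2=NN(c3ccc(S(N)(=O)=O)cc3)C(c3ccccc3O)C2)cc1Cl`, gives 4490 nM in a functional assay on MDA-MB-435 cells (Homo sapiens) for antiproliferative activity, with a stated time of 48 h; a lower number here means a stronger inhibitor of growth, a higher number a weaker inhibitor of growth.
Compound 2, `Cc1cc(O)c(C2=NN(c3ccc(S(N)(=O)=O)cc3)C(/C=C/c3ccccc3)C2)cc1Cl`, gives 24000 nM in this assay.

Among the compounds with values here, of these two numbers compound 2 stands highest, so it is the weaker inhibitor of growth; the only other compound, compound 1, sits below it by a step, a 5.3-fold higher number from compound 1 to compound 2 (0.73 log units; beyond the scatter), that lies beyond the scatter. Compound 3, `COc1ccc(C2CC(c3cc(Cl)c(C)cc3O)=NN2c2ccc(S(N)(=O)=O)cc2)cc1OC`, has not yet been measured. The change from compound 2 to compound 3 is 3,4-dimethoxyphenyl in place of 2-phenylethenyl on a saturated ring carbon. Within the data shown here, the single measured step bears on this only in part: it shows that on this saturated ring carbon a 2-phenylethenyl group gave a higher number than a group that is itself a six-membered aromatic ring without a double bond outside aromatic rings, so going back to such a ring may bring the number down again. Among the measured compounds shown here, compound 3 is therefore expected to give a lower number, a 3.4-fold lower number from compound 2 to compound 3 (0.54 log units; beyond the scatter), in this assay, although the 3,4-dimethoxyphenyl group has no measured counterpart here. The estimate for compound 3 is 7000 nM, with a range from 2500 nM to 20000 nM.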

Compound 3, concentration for total growth inhibition: 24000 nM
Compound 3: middle estimate off by 3.4-fold (0.54 log units), on the low side, and the stated range ends below it.
By their numbers in this assay, from the lowest: compound 1; then compounds 2 and 3 (each within the scatter of the next).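

On this saturated ring carbon, putting 3,4-dimethoxyphenyl in place of 2-phenylethenyl gives no change at the digits printed from compound 2 to compound 3 (within the scatter) in this assay, so removing the double bond outside aromatic rings and adding two methoxy groups does not separate these two compounds. The 2-hydroxyphenyl group of compound 1 still stands apart, with 3,4-dimethoxyphenyl in its place giving a 5.3-fold higher number from compound 1 to compound 3 (0.73 log units; beyond the scatter), which matches the size of the step to compound 2 and shows that a six-membered aromatic ring at this position is not enough on its own to reach the lower number. Nothing available explains these numbers.

The compounds shown leave open whether the lower number of compound 1 goes with the hydroxyl group itself. An unsubstituted phenyl group and a 2-aminophenyl group, neither of which is among them, would bear directly on that question.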